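Ethynylsulfanyl in Place of a Benzylsulfanyl Arm

The source may hold more compounds than are shown below. What is called first, only, known or untested is meant among the compounds shown, and "the series" means these compounds.

Compound 1, `Cc1cc(N2CC[C@@H](C)[C@@H](N(C)c3ncnc4[nH]ccc34)C2)n2ncnc2n1`, gives 11300 nM in a functional assay on HGC-27 cells (Homo sapiens) for inhibition, read by MTT assay, with a stated time of 72 h; a higher number here means a weaker inhibitor, a lower number a stronger inhibitor.
Compound 2, `Cc1cc(N2CC[C@@H](C)[C@@H](N(C)c3ncnc4[nH]ccc34)C2)n2nc(SCC3CCCCC3)nc2n1`, gives 11500 nM in this assay.
Compound 3, `Cc1cc(N2CC[C@@H](C)[C@@H](N(C)c3ncnc4[nH]ccc34)C2)n2nc(SCc3ccc(C(F)(F)F)cc3)nc2n1`, gives 9540 nM in this assay.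

Compound 3 has the lowest of the three numbers, yet its nearest neighbour is compound 1 and its furthest is compound 2, and in both cases the separation is within the scatter, so the three measured compounds cannot be told apart in this assay.

Compound 4, `C#CSc1nc2nc(C)cc(N3CC[C@@H](C)[C@@H](N(C)c4ncnc5[nH]ccc45)C3)n2n1`, has not yet been measured. It differs from compound 3 in one place: ethynyl in place of 4-(trifluoromethyl)benzyl on a sulfur.

For the measured compounds named here, three measured steps bear on this change. Adding a (cyclohexylmethyl)sulfanyl group to the shared core gave a 1.0-fold higher number from compound 1 to compound 2 (0.01 log units; within the scatter); adding a (4-(trifluoromethyl)benzyl)sulfanyl group gave a 1.2-fold lower number from compound 1 to compound 3 (0.07 log units; within the scatter); and exchanging the cyclohexyl for a 4-(trifluoromethyl)phenyl on the carbon bound to sulfur gave a 1.2-fold lower number from compound 2 to compound 3 (0.08 log units; within the scatter). Every variation of the group on that sulfur, from nothing at all to a large aryl or cycloalkyl arm, has left the number where it was. Shrinking the arm to ethynyl is therefore expected to produce no step beyond the scatter, a 1.1-fold higher number from compound 3 to compound 4 (0.04 log units; within the scatter).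

Compound 4 is thus estimated at 10500 nM in this assay, with a range from 4500 nM to 25000 nM.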

Compound 4, half-maximal inhibitory concentration: 35100 nM
Estimate against measurement, compound 4: 3.3-fold (0.52 log units) below; the measured number lies above the stated range.
By their numbers in this assay, from the lowest: compounds 3, 1 and 2 (each within the scatter of the next); then compound 4.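

In this assay, for the compounds shown here, the position that had seemed indifferent to what it carries proves not to be: ethynyl on the sulfur gives a 3.7-fold higher number from compound 3 to compound 4 (0.57 log units; beyond the scatter) and, set against the cyclohexylmethyl arm, a 3.1-fold higher number from compound 2 to compound 4 (0.48 log units; beyond the scatter), the first steps at this place to pass beyond the scatter. The result cannot be read as a simple penalty for a shorter arm, as compound 1, which has only hydrogen on that aromatic carbon, goes against any such trend: ethynylsulfanyl in place of that hydrogen gives a 3.1-fold higher number from compound 1 to compound 4 (0.49 log units; beyond the scatter), so the higher number goes with the ethynylsulfanyl group itself and not with the loss of the larger arm. Nothing available explains why this group departs from the others.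

From the compounds shown here alone, whether the triple bond or the short arm is what counts remains open, and an ethyl or a vinyl group on the same sulfur would separate the two. Also open is whether any group on this sulfur, such as an amine-bearing chain or a carboxylic acid, can lower the number beyond the scatter, as none of the arms shown does.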